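A few compounds are considered here, and "the series" means these few. Any claim that something is new, unique, unknown or untested is made for them only; others in the source may bear on it.

Measured compounds in an ADME assay on microsomes from liver (Homo sapiens) for metabolic stability, with a stated time of 30 min; on this read-out higher numbers stand for a more stable compound and lower numbers for a less stable compound:
- compound 1 `CCCCc1nc(C)c(CC(=O)OCC)c(=O)n1Cc1ccc(-c2ccccc2-c2noc(=O)[nH]2)cc1`: 46.6%; 46.5% (2 entries)
- compound 2 `CCCCc1nc(C)c(CC(=O)OC)c(=O)n1Cc1ccc(-c2ccccc2-c2noc(=O)[nH]2)cc1`: 69.6%
- compound 3 `CCCCc1nc(C)c(CC(=O)OC2CC2)c(=O)n1Cc1ccc(-c2ccccc2-c2noc(=O)[nH]2)cc1`: 34.5%

Compound 3 gives the lowest number of the two single values shown in this assay; the nearest is compound 2, and the step of a number 35.1 percentage points lower from compound 2 to compound 3 (beyond the scatter) lies beyond the scatter. Compound 1 sits between them with its two entries (the several entries of compound 1 in this assay, 46.6%; 46.5% (2 entries)), which agree closely with each other. Compound 4 `CCCCc1nc(C)c(CC(=O)OC2CCCCC2)c(=O)n1Cc1ccc(-c2ccccc2-c2noc(=O)[nH]2)cc1` is not yet measured. It differs from compound 3 in one place: cyclohexyl in place of cyclopropyl on an oxygen next to a carbonyl group.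

Among the compounds with values here, the one measured step that bears on this change is a number 35.1 percentage points lower from compound 2 to compound 3 (beyond the scatter), a large fall when the group on the oxygen next to the carbonyl grows from methyl to cyclopropyl; the values of compound 2, compound 1 and compound 3 fall in the same order as the size of that group. On that basis a further move downward is expected for compound 4, of about a number 12.5 percentage points lower from compound 3 to compound 4 (beyond the scatter), though smaller than the methyl-to-cyclopropyl step since compound 3 already stands low. Compound 4 is therefore estimated at 22%, with a range of 8% to 40%.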

Compound 4, percent of the compound remaining: 3.9%
For compound 4 the middle estimate is 18.1 percentage points above the measured one; the whole stated range lies above it.
By their numbers in this assay, from the lowest: compound 4; then compound 3; then compound 2.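

On an oxygen next to a carbonyl group, the fall seen with cyclopropyl does not level off: in this assay the change to cyclohexyl gives a number 30.6 percentage points lower from compound 3 to compound 4 (beyond the scatter), a second large step in the same direction. Across the full change from methyl to cyclohexyl the result is a number 65.7 percentage points lower from compound 2 to compound 4 (beyond the scatter), and compound 4, at 3.9%, has the lowest number of the single values in this series. Nothing shown gives a cause for these steps.

Still open, going by these compounds, is whether an isopropyl or tert-butyl chain, or a ring carrying an oxygen such as tetrahydropyranyl, would follow the same downward course at this place. Also open, on these data alone, is how the corresponding carboxylic acid or an amide in place of this group would read in this assay.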